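This account rests on a few compounds, and the source may have more. Where it says the series, first, only, none or still open, it means among the compounds named here.

Compound 1 `COc1ncc(-c2ccc3c(c2)N(c2ccc(C)cc2)C(=O)CO3)cc1NS(=O)(=O)c1ccc(F)cc1`: 28300 nM
Compound 2 `O=C1COc2ccc(-c3cnc(Cl)c(NS(=O)(=O)c4ccc(F)cc4)c3)cc2N1c1ccc(F)cc1`: > 40000 nM

Both compounds were tested in a functional assay on HepG2 cells (Homo sapiens) for antiproliferative activity, read by MTT assay, with a stated time of 72 h; on this read-out higher numbers stand for weaker inhibition and lower numbers for stronger inhibition. For compound 2, the entry > 40000 nM is a limit of the assay and not a number. Compound 2 therefore has no exact place on the scale, and the data show only (the limit of > 40000 nM in this assay, at which 1 of the 2 values shown sits).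

Compound 3 `Cc1ccc(N2C(=O)COc3ccc(-c4cnc(Cl)c(NS(=O)(=O)c5ccc(F)cc5)c4)cc32)cc1` matches compound 2 except that a 4-fluorophenyl becomes a 4-methylphenyl, with methyl in place of fluoro on an aromatic carbon. For the measured compounds named here, no measured pair shows what this swap does in this assay, so a small step towards stronger inhibition is expected, perhaps none beyond the usual scatter. Since compound 1 gives 28300 nM, weak inhibition is expected here too. The expected change is an at least 1.1-fold lower number from compound 2 to compound 3 (0.05 log units; that floor lies within the scatter). The estimated value for compound 3 is 35000 nM, with an expected range of 15000 nM to 80000 nM.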

Compound 3, half-maximal inhibitory concentration: 39600 nM
For compound 3 the middle estimate is 1.1-fold (0.05 log units) below the measured one; the measured number falls inside the stated range.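

With the 4-methylphenyl held constant, the change from methoxy to chloro on an aromatic carbon can now be read in this assay: a 1.4-fold higher number from compound 1 to compound 3 (0.15 log units; within the scatter), so these two compounds cannot be told apart. The change from 4-fluorophenyl to 4-methylphenyl gives a number no higher from compound 2 to compound 3 (the limit leaves the size open). Its size cannot be read, because compound 2 carries a limit and not a number: the limit of > 40000 nM in this assay, at which 1 of the 3 values shown sits. Even so, the methyl compound 3 gives a measured number in the same weak range as compound 1.

The compounds shown leave open what an amine, a carboxylic acid or a longer chain would do in place of the methyl on this aromatic carbon, para to a large group. They also leave open how fluoro and methyl compare at this place when methoxy stands in place of chloro.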